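A few compounds are considered here, and "the series" means these few. Any claim that something is new, unique, unknown or untested is made for them only; others in the source may bear on it.

Three compounds share one core and differ only in the group on an amide-type nitrogen. Going by the values given here, compound 1 `O=C(Nc1ccccc1)c1c(NO)cc(-c2ccccc2)oc1=O` carries a phenyl there, and in an ADME assay on Huh-7 cells (Homo sapiens) for cytotoxicity, read by a luciferase reporter and WST assay, with a stated time of 3 days (a lower number here means that less compound is tolerated, a higher number that more compound is tolerated), compound 1 gives 11600 nM, the only plain number among the three values shown. Compound 2 `Cc1ccc(NC(=O)c2c(NO)cc(-c3ccc(C)cc3)oc2=O)cc1` reaches only a limit of the assay, > 20000 nM. Compound 3 `CNC(=O)c1c(NO)cc(-c2ccccc2)oc1=O`, with a methyl in place of the phenyl, also stops at a limit, > 20000 nM. Among the compounds with values here, the one measured step bearing on a change at this nitrogen is an at least 1.7-fold higher number from compound 1 to compound 3 (0.23 log units; that floor lies within the scatter), and its size is set by the limit of > 20000 nM in this assay, at which 2 of the 3 values shown sit, rather than by a measured number.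

Compound 4 `O=C(NCCO)c1c(NO)cc(-c2ccccc2)oc1=O` is not yet measured. Compared with compound 1 it has 2-hydroxyethyl in place of phenyl on an amide-type nitrogen. A smaller group at this nitrogen, in compound 3, moved the number up to the limit, so for compound 4 a rise in this assay is expected, though a rise no larger than the scatter cannot be ruled out. The expected step is a 1.7-fold higher number from compound 1 to compound 4 (0.24 log units; within the scatter). Compound 4 is therefore estimated at 20000 nM, within a range from 9000 nM to 45000 nM.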

Compound 4, half-maximal cytotoxic concentration: > 20000 nM
Compound 4 gave a limit, no number; the forecaster's own chance of this, stated with the estimate: 55%; the middle value sits exactly at the limit.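

With 2-hydroxyethyl on the amide-type nitrogen, this assay gives an at least 1.7-fold higher number from compound 1 to compound 4 (0.23 log units; that floor lies within the scatter), so the result for compound 4 is a limit and not a number. This shows that a second replacement for the phenyl of compound 1, one that brings a hydroxyl and a longer chain than the methyl of compound 3, also ends at a limit. The size of this step rests on that limit, and the step between compound 3 and compound 4 cannot be read: the limit of > 20000 nM in this assay, at which 3 of the 4 values shown sit.

From the compounds shown here alone, how much compound the cells tolerate in compound 3 and compound 4 remains unknown, so the hydroxyl's contribution cannot be separated from that of the chain. Also open, going by these compounds, is whether a 2-aminoethyl group, a carboxylic acid or a longer alkyl chain at this nitrogen would give a plain number.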